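Sulfonylpiperidine series: antiproliferative read-out on DLD-1 cells

The source may report more compounds than this note shows. Statements on the series, on what has been measured and on what is new or still open speak of the compounds shown alone.

Measured so far:
compound 1 `CC1CCN(C2CCN(S(=O)(=O)c3ccc(C(C)(C)C)cc3)CC2)CC1` gives > 5000 nM
compound 2 `Cc1cc(C)c(S(=O)(=O)N2CCC(C(=O)N3CCC(C)CC3)CC2)c(C)c1` gives > 5000 nM
compound 3 `Cc1cc(C)c(S(=O)(=O)N2CCN(C3CCN(C)CC3)CC2)c(C)c1` gives 426 nM

In a functional assay on DLD-1 cells (Homo sapiens) for antiproliferative activity, read by CellTiter-Glo, with a stated time of 72 h (on this read-out higher numbers stand for weaker inhibition and lower numbers for stronger inhibition), compound 1 reaches only a limit of the assay. Within the data shown here, compound 2 also sits at a limit in this assay, so no number is known for it; it stands at the limit of > 5000 nM in this assay, at which 2 of the 3 values shown sit, together with compound 1, while compound 3 is the one compound with a numerical value. Compound 4 `Cc1cc(C)c(S(=O)(=O)N2CCC(N3CCCCC3)CC2)c(C)c1` is not yet measured. It differs from compound 2 by piperidin-1-yl in place of (4-methylpiperidin-1-yl)carbonyl on a saturated ring carbon. Among the measured compounds shown here, with no measured step between any two compounds, the size of this step cannot be read from the data; the expectation is a step toward stronger inhibition of an at least 3.3-fold lower number from compound 2 to compound 4 (0.52 log units; beyond the scatter), possibly beyond the scatter. Compound 4 is therefore estimated at 1500 nM, within 300 nM to 6000 nM.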

Compound 4, half-maximal inhibitory concentration: 2200 nM
Estimate against measurement, compound 4: 1.5-fold (0.17 log units) below; measured number inside the range.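

In this assay piperidin-1-yl in place of (4-methylpiperidin-1-yl)carbonyl on the saturated ring carbon gives an at least 2.2-fold lower number from compound 2 to compound 4 (0.35 log units; beyond the scatter) and is the only step readable among the compounds shown. This change removes the carbonyl and the methyl together, and it shows that this position responds to the group it carries. The size of the step is only a bound, since the value of compound 2 is a limit and not a number: the limit of > 5000 nM in this assay, at which 2 of the 4 values shown sit.

The carbonyl and the methyl cannot be separated here. On these data alone, whether dimethylamino or a carboxylic acid on this ring carbon would lower the number further stays open.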